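The source may hold more compounds than are shown below. What is called first, only, known or untested is meant among the compounds shown, and "the series" means these compounds.

Series notes, cytotoxicity. In an ADME assay on CCRF-HSB-2 cells (Homo sapiens) for cytotoxicity, with a stated time of 7 days (a higher number here means that more compound is tolerated, a lower number that less compound is tolerated), compound 1 `COCCOc1nc(N)nc2c1ncn2/C=C1/CC1(CO)CO` gives > 20000 nM, which is a limit of the assay rather than a number. Compound 2 `CN(C)c1nc(N)nc2c1ncn2/C=C1/CC1(CO)CO` gives in this assay > 20000 nM, again a limit. Compound 3 `Nc1nc(NC2CCCC2)c2ncn(/C=C3/CC3(CO)CO)c2n1` gives in this assay > 20000 nM, also a limit. Compound 1 thus stands at the limit together with the other measured compounds: the limit of > 20000 nM in this assay, at which 3 of the 3 values shown sit. The steps a step that the two limits leave unreadable from compound 1 to compound 2, a step that the two limits leave unreadable from compound 1 to compound 3 and a step that the two limits leave unreadable from compound 2 to compound 3 are all unreadable; both ends of each sit at a limit.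

Compound 4 `Nc1nc(NC2CCCCC2)c2ncn(/C=C3/CC3(CO)CO)c2n1` is not yet measured. It differs from compound 1 as follows: cyclohexylamino in place of 2-methoxyethoxy on an aromatic carbon. Among the measured compounds shown here, the nearest measured step is the one from compound 1 to compound 3, where cyclopentylamino replaces the same group on the same carbon, and its size is unreadable because the limit of > 20000 nM in this assay, at which 3 of the 3 values shown sit, places both values at the limit. For the measured compounds named here, no measured step reads as beyond the scatter; the expectation for compound 4 in this assay is therefore no step beyond the scatter, that is a step that the limit leaves unreadable from compound 1 to compound 4, most likely again a limit. Compound 4 is estimated at 30000 nM, with a range from 10000 nM to 100000 nM.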

Compound 4, half-maximal cytotoxic concentration: > 20000 nM
Compound 4: no number, only a limit; the forecaster's own chance of this, stated with the estimate: 85%; the middle value lies beyond the limit too.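

Compound 4 gives > 20000 nM in this assay, again a limit and not a number, and its steps from compound 1, compound 2 and compound 3 cannot be read: the limit of > 20000 nM in this assay, at which 4 of the 4 values shown sit. The compounds shown leave open whether the groups at this place differ at all in this assay.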